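Methyl in place of 4-fluorophenyl: toxicity notes

The source may report more compounds than this note shows. Statements on the series, on what has been measured and on what is new or still open speak of the compounds shown alone.

In a toxicity assay on THP-1 cells (Homo sapiens) for inhibition (on this read-out lower numbers stand for higher toxicity in this test and higher numbers for lower toxicity in this test), compound 3 (`COc1ccc(-c2cnc(NC(=O)c3ccc(F)cc3)n2C)cc1`) gives >= 50000 nM, which is a limit and not a number. Compound 1 (`COc1ccc(-c2cnc(NC(=O)c3ccc(Br)cc3)n2C)cc1`) gives > 100000 nM, also a limit. Compound 2 (`COc1ccc(-c2cnc(NC(=O)c3cccc(O)c3)n2C)cc1`) gives > 100000 nM, again a limit.

Compound 4 (`COc1ccc(-c2cnc(NC(C)=O)n2C)cc1`) carries methyl in place of 4-fluorophenyl on a carbonyl carbon.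

The measured steps that bear on this change are a step that the two limits leave unreadable from compound 1 to compound 3, a step that the two limits leave unreadable from compound 2 to compound 3 and a step that the two limits leave unreadable from compound 1 to compound 2. None has a readable size, so no step beyond the scatter is expected in this assay, in either direction. The expected step is a step that the limit leaves unreadable from compound 3 to compound 4. For compound 4 the estimated value is 100000 nM, with an expected range from 50000 nM to 200000 nM.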

Compound 4, half-maximal cytotoxic concentration: > 100000 nM
Compound 4: a limit, no number; the forecaster's own chance of this, stated with the estimate: 90%; the middle value sits exactly at the limit.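

Among the compounds shown here, compounds 1, 2, 3 and 4 all give only limits in this assay, so no step between compound 4 and compounds 1, 2 or 3 can be read. The compounds shown leave open whether the group on the carbonyl carbon shifts this read-out at all.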